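Swapping cyclohexyl for isopropyl on compound 1

A few compounds are considered here, and "the series" means these few. Any claim that something is new, unique, unknown or untested is made for them only; others in the source may bear on it.

In a functional assay on A549 cells (Homo sapiens) for antiproliferative activity, read by MTT assay, with a stated time of 72 h (on this read-out higher numbers stand for weaker inhibition and lower numbers for stronger inhibition), compound 1 `O=C1COc2ccc(-c3cnc(Cl)c(NS(=O)(=O)c4ccc(F)cc4)c3)cc2N1C1CCCCC1` gives 37900 nM. Compound 3 `COc1ncc(-c2ccc3c(c2)N(C2CCCCC2)C(=O)CO3)cc1NS(=O)(=O)c1ccc(F)cc1` gives 24600 nM, which lies within the scatter of compound 1. Compound 2 `COc1cccc(N2C(=O)COc3ccc(-c4cnc(OC)c(NS(=O)(=O)c5ccc(F)cc5)c4)cc32)c1` gives 11200 nM, a lower number than either of the other two.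

Compound 4 `CC(C)N1C(=O)COc2ccc(-c3cnc(Cl)c(NS(=O)(=O)c4ccc(F)cc4)c3)cc21` keeps the core of compound 1 and carries isopropyl in place of cyclohexyl on an amide-type nitrogen in a ring.

One measured step falls at this place: a 2.2-fold higher number from compound 2 to compound 3 (0.34 log units; beyond the scatter), with cyclohexyl in place of 3-methoxyphenyl. Going by the values given here, it is modest, but it involves a different pair of groups, and no measured compound carries isopropyl. The other step, a 1.5-fold lower number from compound 1 to compound 3 (0.19 log units; within the scatter), is methoxy in place of chloro on an aromatic carbon. It lies elsewhere on the core and gives no guide to the change at the nitrogen.

With the step from compound 2 as the only size reference, a small shift towards a lower number in this assay is expected, though the direction is weakly supported. The expected size is a 1.3-fold lower number from compound 1 to compound 4 (0.10 log units; within the scatter), so no change beyond the scatter is foreseen. Compound 4 is estimated at 30000 nM, with an expected range from 12000 nM to 70000 nM.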

Compound 4, half-maximal inhibitory concentration: 5100 nM
Estimate against measurement, compound 4: 5.9-fold (0.77 log units) above; measured number below the stated range.
By their numbers in this assay, from the lowest: compound 4; then compound 2; then compounds 3 and 1 (each within the scatter of the next).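

In this assay, the amide-type nitrogen in a ring turns out to be a place where a change of carbon group alone can move the number beyond the scatter: isopropyl in place of cyclohexyl gives a 7.4-fold lower number from compound 1 to compound 4 (0.87 log units; beyond the scatter) with the chloro kept on the core. The group that leaves has 6 heavy atoms and a six-membered carbon ring, the one that enters has 3 heavy atoms and no ring, and neither has hydrogen-bond donors, hydrogen-bond acceptors or a net charge; together with a 2.2-fold higher number from compound 2 to compound 3 (0.34 log units; beyond the scatter) this makes two pairs at this nitrogen in which the cyclohexyl compound has the higher number, and no pair shown goes against that. No measurement shown explains the size of this step, so its cause stays unassigned.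

Still open is whether isopropyl gives a similar step on the methoxy version of the core, as the only pair shown for this change carries chloro. Also open, going by these compounds, is how the number responds to methyl, ethyl, a longer chain such as n-butyl, or a chain ending in an amine on this nitrogen.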